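A Methylated Thiophene Replaces a Plain One

The compounds below may be only part of what the source reports. "The series", "measured", "known", "first", "only" and "open" are said of these compounds alone.

In a functional assay on MV4-11 cells (Homo sapiens) for inhibition, read by resazurin assay, with a stated time of 72 h (on this read-out lower numbers stand for stronger inhibition of growth and higher numbers for weaker inhibition of growth), compound 1 `O=C1NCCC12CCN(c1c(Cl)cncc1-c1ccoc1)CC2` gives 750 nM and compound 2 `O=C1NCCC12CCN(c1c(Cl)cncc1-c1ccsc1)CC2` gives 190 nM, the lower of the two numbers and so the stronger growth inhibition. Compound 3 `Cc1ccsc1-c1cncc(Cl)c1N1CCC2(CCNC2=O)CC1` keeps the shared core but changes one group: 3-methylthiophen-2-yl in place of thiophen-3-yl on an aromatic carbon. Among the compounds with values here, only one measured step bears on this, and only loosely: a 3.9-fold lower number from compound 1 to compound 2 (0.60 log units; beyond the scatter), a modest change beyond the scatter, where thiophen-3-yl took the place of furan-3-yl. That step shows that swapping this ring can move the number in this assay, but it tests neither an added methyl nor a thiophene joined through a different ring carbon. No step beyond the scatter is therefore expected, in either direction, and the estimated step is a 1.3-fold higher number from compound 2 to compound 3 (0.12 log units; within the scatter). For compound 3 the estimated value is 250 nM, with an expected range of 70 nM to 900 nM.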

Compound 3, concentration for 50% growth inhibition: 910 nM
Estimate against measurement, compound 3: 3.6-fold (0.56 log units) below; the whole stated range lies below it.
By their numbers in this assay, from the lowest: compound 2; then compounds 1 and 3 (each within the scatter of the next).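

In this assay, putting 3-methylthiophen-2-yl on this aromatic carbon gives a 4.8-fold higher number from compound 2 to compound 3 (0.68 log units; beyond the scatter), so the position does not treat every thiophene alike. The stronger growth inhibition of thiophen-3-yl over furan-3-yl therefore does not carry over to this thiophene, which gives a 1.2-fold higher number from compound 1 to compound 3 (0.08 log units; within the scatter), a difference that stays within the scatter. The data shown offer no explanation for this loss.

The new group differs from thiophen-3-yl in two ways at once, an added methyl and a different ring carbon carrying the link, and the compounds shown do not separate the two. Still open, as far as these compounds go, is how a plain thiophen-2-yl, a 4-methylthiophen-3-yl or a phenyl ring would behave at this position.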